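Lengthening the Amine-Bearing Chain on the Amide Nitrogen

This account rests on a few compounds, and the source may have more. Where it says the series, first, only, none or still open, it means among the compounds named here.

Three measured compounds share one core and differ only in the group on the amide-type nitrogen. Compound 1 `CC(C)N1CC[C@H](NC(=O)c2cc(-c3ccc(NS(=O)(=O)c4cccc(Cl)c4Cl)cc3)nc3[nH]ncc23)C1` gives 38 nM in an assay for inhibition of serine/threonine-protein kinase Sgk1 (Homo sapiens), with stated times of 30 min and 60 min, in the presence of a further agent that is not named here; a lower number here means a stronger inhibitor, a higher number a weaker inhibitor. Compound 2 `CC(C)NC(=O)c1cc(-c2ccc(NS(=O)(=O)c3cccc(Cl)c3Cl)cc2)nc2[nH]ncc12` gives 17600 nM, a step of a 460-fold higher number from compound 1 to compound 2 (2.67 log units; beyond the scatter). Compound 3 `NCCNC(=O)c1cc(-c2ccc(NS(=O)(=O)c3cccc(Cl)c3Cl)cc2)nc2[nH]ncc12` reaches the limit of this assay, < 1 nM, so only a limit is known for it. The steps of an at least 38-fold lower number from compound 1 to compound 3 (1.57 log units; beyond the scatter) and an at least 17000-fold lower number from compound 2 to compound 3 (4.24 log units; beyond the scatter) place compound 3 as the strongest of the three, sitting at the limit of < 1 nM in this assay, at which 1 of the 3 values shown sits. Compound 4 `CN(C)CCCNC(=O)c1cc(-c2ccc(NS(=O)(=O)c3cccc(Cl)c3Cl)cc2)nc2[nH]ncc12` differs from compound 3 by (dimethylamino)methyl in place of amino on a saturated chain carbon, two bonds along the chain from an amide-type nitrogen. Both measured steps toward compound 3 gained with an amine on the chain, and compound 4 keeps one, so the expected step of an at least 1.5-fold higher number from compound 3 to compound 4 (0.17 log units; that floor lies within the scatter) is small. Compound 4 is estimated at 1.5 nM, between 0.3 nM and 8 nM.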

Compound 4, half-maximal inhibitory concentration: 633 nM
Beside the measured number, compound 4's estimate is 420-fold (2.63 log units) below it; the whole stated range lies below it.
By their numbers in this assay, from the lowest: compound 1; then compound 4; then compound 2. At a limit, below all of these: compound 3.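

An amine on the chain does not by itself keep the number low, since 3-(dimethylamino)propyl in place of 2-aminoethyl gives an at least 630-fold higher number from compound 3 to compound 4 (2.80 log units; beyond the scatter). The same amine-bearing chain still improves on plain isopropyl (a 28-fold lower number from compound 2 to compound 4 (1.44 log units; beyond the scatter)) but falls short of 1-isopropylpyrrolidin-3-yl (a 17-fold higher number from compound 1 to compound 4 (1.22 log units; beyond the scatter)). The step from compound 3 rests on a limit: the limit of < 1 nM in this assay, at which 1 of the 4 values shown sits.

As far as these compounds go, what remains open is whether the longer chain or the dimethylamino end drives the change. A 3-aminopropyl group and a 2-(dimethylamino)ethyl group on the amide nitrogen would separate the two.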